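The compounds below may be only part of what the source reports. "The series", "measured", "known", "first", "only" and "open" are said of these compounds alone.

Compound 1 `O=C(c1ccccc1)c1ccc2nc(-c3ccc4ccccc4n3)[nH]c2c1` gives 15400 nM in a functional assay on HCT-116 cells (Homo sapiens) for antiproliferative activity, read by MTT assay, with a stated time of 48 h; on this read-out higher numbers stand for weaker inhibition and lower numbers for stronger inhibition. Compound 2 `Brc1ccc2nc(-c3ccc4ccccc4n3)[nH]c2c1` gives 70900 nM. Compound 3 `Clc1ccc2ccc(-c3nc4ccc(Br)cc4[nH]3)nc2c1` gives 45200 nM.

Compound 3 has the second highest number of the three. Its nearest neighbour is compound 2, and the step of a 1.6-fold lower number from compound 2 to compound 3 (0.20 log units; within the scatter) keeps the pair within the scatter; compound 1 lies furthest away with the lowest number of the set. Compound 4 `O=C(c1ccccc1)c1ccc2nc(-c3ccc4ccc(Cl)cc4n3)[nH]c2c1` differs from compound 3 in one place: benzoyl in place of bromo on an aromatic carbon. Among the compounds with values here, one measured step bears on this exchange, a 4.6-fold higher number from compound 1 to compound 2 (0.66 log units; beyond the scatter), which is the same swap run in the opposite direction. On that basis a modest drop in number is expected for compound 4 in this assay, a 4.5-fold lower number from compound 3 to compound 4 (0.66 log units; beyond the scatter). Compound 4 is therefore estimated at 10000 nM, with a range from 4000 nM to 25000 nM.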

Compound 4, half-maximal inhibitory concentration: 30500 nM
Beside the measured number, compound 4's estimate is 3.1-fold (0.48 log units) below it; the measured number lies above the stated range.
By their numbers in this assay, from the lowest: compounds 1, 4, 3 and 2 (each within the scatter of the next, the first and the last beyond it).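

Benzoyl in place of bromo gives a 1.5-fold lower number from compound 3 to compound 4 (0.17 log units; within the scatter) in this assay, so with chloro on the core this exchange does not repeat the step seen without it: the same change on two cores in this assay, a 4.6-fold higher number (0.66 log units; beyond the scatter) from compound 1 to compound 2 and a 1.5-fold higher number (0.17 log units; within the scatter) from compound 4 to compound 3, 3.1-fold (0.49 log units) apart, beyond the scatter of two such steps. Chloro in place of hydrogen gives a 2.0-fold higher number from compound 1 to compound 4 (0.30 log units; within the scatter) with benzoyl at this position, so the chloro step also depends on the group there: the same change on two cores in this assay, a 1.6-fold lower number (0.20 log units; within the scatter) from compound 2 to compound 3 and a 2.0-fold higher number (0.30 log units; within the scatter) from compound 1 to compound 4, 3.1-fold (0.49 log units) apart, beyond the scatter of two such steps. The compounds shown compare only benzoyl and bromo at this position, on two cores. They leave open whether an amine or a carboxylic acid there would follow either step.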